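Benzyloxycarbonyl in place of trifluoromethyl: compound 4

The compounds below may be only part of what the source reports. "The series", "measured", "known", "first", "only" and "open" are said of these compounds alone.

- compound 1 `O=C(OCc1ccccc1)c1ccc2[nH]c(-c3cn(-c4ccccc4)nc3-c3ccc(F)cc3)nc2c1`: 23600 nM
- compound 2 `COc1ccc2[nH]c(-c3cn(-c4ccccc4)nc3-c3ccc(Cl)cc3)nc2c1`: 3630 nM
- compound 3 `FC(F)(F)c1ccc2[nH]c(-c3cn(-c4ccccc4)nc3-c3ccc(Cl)cc3)nc2c1`: 4420 nM

In a functional assay on HeLa cells (Homo sapiens) for antiproliferative activity, read by MTT assay, with a stated time of 48 h (a higher number here means a weaker inhibitor, a lower number a stronger inhibitor), compound 3 gives 4420 nM. It stands level with compound 2 within the scatter, while compound 1 reads 23600 nM, a clearly higher number. The change to compound 4 `O=C(OCc1ccccc1)c1ccc2[nH]c(-c3cn(-c4ccccc4)nc3-c3ccc(Cl)cc3)nc2c1` is benzyloxycarbonyl in place of trifluoromethyl on an aromatic carbon.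

Going by the values given here, one measured step bears directly on that aromatic carbon, trifluoromethyl in place of methoxy: a 1.2-fold higher number from compound 2 to compound 3 (0.09 log units; within the scatter). It involves a much smaller group than the one entering here, so it offers only limited guidance. Compound 1 already carries benzyloxycarbonyl and reads 23600 nM, but it has fluorine where compound 4 has chlorine, and no exchange of those two halogens has been measured. The expected step is towards a higher number and beyond the scatter: a 4.1-fold higher number from compound 3 to compound 4 (0.61 log units; beyond the scatter). For compound 4 the estimate is 18000 nM, with an expected range from 8000 nM to 38000 nM.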

Compound 4, half-maximal inhibitory concentration: 8130 nM
Estimate against measurement, compound 4: 2.2-fold (0.35 log units) above, and the stated range covers the measured number.
By their numbers in this assay, from the lowest: compounds 2, 3 and 4 (each within the scatter of the next, the first and the last beyond it); then compound 1.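

In this assay, benzyloxycarbonyl, with 10 heavy atoms, is accepted at this aromatic carbon in place of trifluoromethyl, with 4 heavy atoms, and the step stays level: a 1.8-fold higher number from compound 3 to compound 4 (0.26 log units; within the scatter). Set against methoxy, the same group gives a modest step that does pass the scatter: a 2.2-fold higher number from compound 2 to compound 4 (0.35 log units; beyond the scatter). With benzyloxycarbonyl held fixed, chloro in place of fluoro gives a 2.9-fold lower number from compound 1 to compound 4 (0.46 log units; beyond the scatter), so the high number of compound 1 does not follow from benzyloxycarbonyl alone.

Nothing at hand explains these steps. Still open, as far as these compounds go, are how an amine or a carboxylic acid at this aromatic carbon would read, and whether the chloro for fluoro step holds with methoxy or trifluoromethyl in place of benzyloxycarbonyl.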